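Dropping a Fluorine Atom: What Compound 4 May Show

The source may hold more compounds than are shown below. What is called first, only, known or untested is meant among the compounds shown, and "the series" means these compounds.

Of the compounds shown here, three from the same series have been tested in an ADME assay on microsomes from liver (Homo sapiens) for metabolic stability, with a stated time of 30 min, tested at 1 uM; on this read-out higher numbers stand for a more stable compound and lower numbers for a less stable compound. Compound 1 `CC[C@@H]1C(=O)N(C)c2cnc(-n3ccnc3-c3ccccc3)nc2N1C1CCCC1` gives 0%, compound 2 `CC[C@@H]1C(=O)N(C)c2cnc(-n3ccnc3-c3ccc(F)cc3)nc2N1[C@H]1CCOC1` gives 58%, and compound 3 `CC(C)N1c2nc(-n3ccnc3-c3ccc(F)cc3)ncc2N(C)C(=O)C1(C)C` gives 54%. Compound 2 thus stands at the top of the numbers seen so far, though its reading and that of compound 3 lie within the usual scatter of each other, so the two cannot be ranked. The reading of compound 1 lies far below both, well beyond the scatter.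

Compound 4 `CC[C@@H]1C(=O)N(C)c2cnc(-n3ccnc3-c3ccccc3)nc2N1[C@H]1CCOC1` has not yet been measured. It differs from compound 2 in one place: hydrogen in place of fluoro on an aromatic carbon. Among the compounds with values here, no pair of measured compounds differs by exactly this change, so the size of the step is not known from this series. Compound 1, which also carries a phenyl without fluoro, sits at 0%, but it differs from compound 2 in a second place as well, so its low reading cannot be laid on the fluoro alone. A fall in this assay is expected, and the step from compound 2 to compound 4 is estimated at a number 20 percentage points lower from compound 2 to compound 4 (beyond the scatter). Compound 4 is therefore expected to give about 38%, within a range from 15% to 58%.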

Compound 4, percent of the compound remaining: 17%
For compound 4 the middle estimate is 21 percentage points above the measured one; low and high end bracket the measured number.
By their numbers in this assay, from the lowest: compound 1; then compound 4; then compounds 3 and 2 (each within the scatter of the next).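

The readings in this assay give a number 41 percentage points lower from compound 2 to compound 4 (beyond the scatter) for 4-fluorophenyl to phenyl with the rest of the structure unchanged, so the swap of this one atom on the aromatic carbon para to a large group is a large step. They also give a number 17 percentage points higher from compound 1 to compound 4 (beyond the scatter) for oxolan-3-yl in place of cyclopentyl, a modest step, which shows that the reading of compound 1 cannot be laid on one of these two places alone. With oxolan-3-yl kept, the loss of fluoro is not made up, and the fluoro step is the larger of the two.

From the compounds shown here alone, whether chloro, methoxy or a nitrile on that same aromatic carbon would behave like fluoro, and how 4-fluorophenyl would read alongside cyclopentyl, stays open. Nothing shown speaks to the cause of either step.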